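Pyridine-linked hydroxyphenyls: a positional swap awaiting its result

The source may report more compounds than this note shows. Statements on the series, on what has been measured and on what is new or still open speak of the compounds shown alone.

Measured so far:
- compound 1 `Oc1cccc(-c2cc(-c3cccs3)cc(-c3ccccc3O)n2)c1` gives in a functional assay on HCT-15 cells (Homo sapiens) for cytotoxicity, read by CCK-8 assay (a lower number here means a stronger inhibitor, a higher number a weaker inhibitor), only a limit, > 50000 nM.
- compound 2 `Oc1ccc(-c2cc(-c3cccs3)cc(-c3ccccc3O)n2)cc1` gives in this assay likewise a limit, > 50000 nM.
- compound 3 `Oc1cccc(-c2cc(-c3ccoc3)cc(-c3cccc(O)c3)n2)c1` gives in this assay a number, 1020 nM.

Three compounds share a central six-membered ring bearing one nitrogen, with three aromatic arms attached. In compound 1 and compound 2 one arm is a thiophen-2-yl ring and another a 2-hydroxyphenyl ring; in compound 3 these arms are a furan-3-yl ring and a 3-hydroxyphenyl ring. How the core of compound 3 differs from the core of compound 1 is not broken down here.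

From compound 1 to compound 2 one arm changes: 4-hydroxyphenyl in place of 3-hydroxyphenyl on an aromatic carbon. Both values sit at the limit of > 50000 nM in this assay, at which 2 of the 3 values shown sit, so the step that the two limits leave unreadable from compound 1 to compound 2 cannot be read in either direction.

The unmeasured compound 4 `Oc1ccc(-c2cc(-c3ccoc3)cc(-c3cccc(O)c3)n2)cc1` carries the same kind of change against compound 3: 4-hydroxyphenyl in place of 3-hydroxyphenyl on an aromatic carbon. The surroundings differ from the earlier pair: here the changed arm sits meta to a 3-hydroxyphenyl group and meta to a furan-3-yl group, whereas in compound 1 it sits meta to a 2-hydroxyphenyl group and meta to a thiophen-2-yl group.

With the earlier step unreadable, the expected step from compound 3 to compound 4 in this assay is a 1.5-fold higher number from compound 3 to compound 4 (0.17 log units; within the scatter), resting only on the assumption that moving a hydroxyl around a phenyl ring leaves potency roughly where compound 3 stands at 1020 nM. Compound 4 is therefore estimated at 1500 nM, with a plausible range from 400 nM to 8000 nM.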

Compound 4, half-maximal inhibitory concentration: 930 nM
Compound 4: the middle estimate sits 1.6-fold (0.21 log units) above what was measured; the range from low to high includes it.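

In this assay, exchanging the 3-hydroxyphenyl arm for a 4-hydroxyphenyl arm on the core of compound 3 gives a 1.1-fold lower number from compound 3 to compound 4 (0.04 log units; within the scatter), so on this core the two arms cannot be told apart. That is one readable step on one core, and it supports no rule about this exchange across the series, even though the opening estimate assumed little would happen. It also does not show that the exchange carries over from the core of compound 1, where the same change cannot be read because compound 1 and compound 2 each give only a limit rather than a number: the limit of > 50000 nM in this assay, at which 2 of the 4 values shown sit.

The compounds shown leave open how furan-3-yl and thiophen-2-yl compare on an otherwise unchanged core, and what a 2-hydroxyphenyl arm would give in place of the 3-hydroxyphenyl arm that compound 3 and compound 4 share. They also leave open whether the reading would stay where it is if the hydroxyl on the exchanged arm gave way to a different group, such as an amine or a carboxylic acid.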